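Exposure after one ring swap on the shared core

The source may report more compounds than this note shows. Statements on the series, on what has been measured and on what is new or still open speak of the compounds shown alone.

Compound 1 `Cn1nccc1-c1cc(C(F)(F)F)ccc1[C@H]1CCOc2cc(S(=O)(=O)Nc3nccs3)ccc21` gives 1150 ng.h/mL
Compound 2 `O=S(=O)(Nc1nccs1)c1ccc2c(c1)OCC[C@@H]2c1ccc(C(F)(F)F)cc1-n1ccnn1` gives 457 ng.h/mL

In an ADME assay on the whole organism (Mus musculus, strain BALB/c), read by LC-MS, with a stated time of 24 h, at a dose of 1 mg/kg by the intravenous route (on this read-out lower numbers stand for lower exposure and higher numbers for higher exposure at the dose given), compound 2 (457 ng.h/mL) is the lower of the two measured compounds. Compound 3 `O=S(=O)(Nc1nccs1)c1ccc2c(c1)OCC[C@@H]2c1ccc(C(F)(F)F)cc1-c1ccc(F)nc1` carries 6-fluoropyridin-3-yl in place of 1H-1,2,3-triazol-1-yl, ortho to a large group (6-fluoropyridin-3-yl in place of 1H-1,2,3-triazol-1-yl on an aromatic carbon). Going by the values given here, only one measured step changes this same place (a 2.5-fold lower number from compound 1 to compound 2 (0.40 log units; beyond the scatter)), and it is modest. Among the compounds with values here, no measured compound carries the entering ring, so only a modest upward step, no larger than that one, is expected. That means an expected 1.6-fold higher number from compound 2 to compound 3 (0.22 log units; within the scatter) in this assay (an uncertain guess). Compound 3 is estimated at 750 ng.h/mL (from 300 ng.h/mL to 1800 ng.h/mL).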

Compound 3, area under the concentration-time curve in the Mus musculus assay: 1070 ng.h/mL
Beside the measured number, compound 3's estimate is 1.4-fold (0.15 log units) below it; low and high end bracket the measured number.
By their numbers in the Mus musculus assay, from the lowest: compound 2; then compounds 3 and 1 (each within the scatter of the next).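

In the Mus musculus assay, 6-fluoropyridin-3-yl restores what 1H-1,2,3-triazol-1-yl gave up at this place (a 2.3-fold higher number from compound 2 to compound 3 (0.37 log units; beyond the scatter)) and stands level with 1-methyl-1H-pyrazol-5-yl (a 1.1-fold lower number from compound 1 to compound 3 (0.03 log units; within the scatter)). Among these three compounds, the low number therefore belongs to compound 2 alone, so this place does not penalise every ring change. The rise from the triazole comes with higher lipophilicity in a physicochemical assay for lipophilicity; a higher number here means a more lipophilic compound, a lower number a more polar compound: the measured distribution coefficient of compound 2, 2.3, and of compound 3, 3.2, a number 0.90 log units higher (beyond the scatter). In the physicochemical assay, compound 2 gives 2.3 and compound 3 gives 3.2. One pair cannot show whether exposure follows lipophilicity in general. On these data alone, how a ring carrying an amine or a carboxylic acid would fare at this place also remains open.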